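A Fluorine on the Anilino Ring of Compound 2

This account rests on a few compounds, and the source may have more. Where it says the series, first, only, none or still open, it means among the compounds named here.

Compound 1, `O=C(CSc1nc(Nc2ccccc2)c2ccccc2n1)Nc1cccc(F)c1`, gives 15600 nM in a functional assay on PC-3 cells (Homo sapiens) for inhibition, read by MTT assay, with a stated time of 72 h; on this read-out higher numbers stand for weaker inhibition and lower numbers for stronger inhibition.
Compound 2, `C=CC(=O)Nc1cccc(NC(=O)CSc2nc(Nc3ccccc3)c3ccccc3n2)c1`, gives 8740 nM in this assay.
Compound 3, `CCc1ccc(NC(=O)CSc2nc(Nc3ccccc3)c3ccccc3n2)cc1`, gives 17900 nM in this assay.

In this assay compound 2 holds the lowest of the three numbers: the step of a 1.8-fold lower number from compound 1 to compound 2 (0.25 log units; within the scatter) stays within the scatter, while a 2.0-fold higher number from compound 2 to compound 3 (0.31 log units; beyond the scatter) is a modest step beyond it. Compound 4, `C=CC(=O)Nc1cccc(NC(=O)CSc2nc(Nc3ccccc3F)c3ccccc3n2)c1`, differs from compound 2 by fluoro in place of hydrogen on an aromatic carbon. Going by the values given here, none of the measured steps touches this ring; all three vary only the group on the amide-type nitrogen, so they give no direct guide to the new change. With nothing pointing either way, a step of no more than the usual scatter is expected, a 1.0-fold lower number from compound 2 to compound 4 (0.01 log units; within the scatter). Compound 4 is therefore estimated at 8500 nM, with a range from 3500 nM to 21000 nM.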

Compound 4, half-maximal inhibitory concentration: 9340 nM
The estimate for compound 4 lay 1.1-fold (0.04 log units) below the measured number; low and high end bracket the measured number.
By their numbers in this assay, from the lowest: compounds 2, 4, 1 and 3 (each within the scatter of the next, the first and the last beyond it).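

Fluoro on the anilino ring, which turns phenyl into 2-fluorophenyl, is the first change shown on this ring, and it gives a 1.1-fold higher number from compound 2 to compound 4 (0.03 log units; within the scatter) in this assay. Going by these compounds alone, at this place, ortho to a large group, a single fluorine therefore leaves the number within the scatter, something the earlier steps on the amide-type nitrogen could not show. No measurement given here offers an explanation for this result. Open, from the compounds shown here alone, is whether a chlorine, a methoxy group or an amine at this place would shift the number beyond the scatter. Also open, going by these compounds, is whether fluoro elsewhere on this ring would do so.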